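This account rests on a few compounds, and the source may have more. Where it says the series, first, only, none or still open, it means among the compounds named here.

In an ADME assay on HaCaT cells (Homo sapiens) for inhibition (on this read-out higher numbers stand for weaker inhibition and lower numbers for stronger inhibition), compound 3 `COc1cc(-c2cc(C(=O)O)c3ccccc3n2)ccc1OCC(=O)Nc1cccc(C(F)(F)F)c1` gives 160000 nM. Among the three compounds sharing this core, compound 3 holds the lowest of the two numbers reported outright, and its nearest neighbour is compound 1 `COc1cc(-c2cc(C(=O)O)c3ccccc3n2)ccc1OCC(=O)Nc1ccccc1F`, which gives 161000 nM; the two sit within the scatter of each other, as a 1.0-fold lower number from compound 1 to compound 3 (0.00 log units; within the scatter) shows. Compound 2 `COc1cc(-c2cc(C(=O)O)c3ccccc3n2)ccc1OCC(=O)Nc1ccc(Cl)cc1` returns only a limit in this assay, > 300000 nM, a case of the limit of > 300000 nM in this assay, at which 1 of the 3 values shown sits. The step of an at least 1.8-fold lower number from compound 2 to compound 3 (0.27 log units; that floor lies within the scatter) has a floor that itself lies within the scatter.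

Compound 4 `COc1cc(-c2cc(C(=O)O)c3ccccc3n2)ccc1OCC(=O)NC1CCCCC1` differs from compound 3 by cyclohexyl in place of 3-(trifluoromethyl)phenyl on an amide-type nitrogen. Going by the values given here, every measured step so far exchanges one aryl group on that nitrogen for another, and none moves beyond the scatter: an at least 1.8-fold higher number from compound 1 to compound 2 (0.27 log units; that floor lies within the scatter), a 1.0-fold lower number from compound 1 to compound 3 (0.00 log units; within the scatter), an at least 1.8-fold lower number from compound 2 to compound 3 (0.27 log units; that floor lies within the scatter). Among the compounds with values here, no measured step exchanges an aromatic ring for a saturated one, so the expectation for compound 4 rests on the flat picture across compounds 1 to 3. Compound 4 is expected to give about 170000 nM in this assay, with a range from 80000 nM to 300000 nM. The step of a 1.1-fold higher number from compound 3 to compound 4 (0.03 log units; within the scatter) is therefore expected to stay within the scatter.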

Compound 4, half-maximal inhibitory concentration: > 300000 nM
Compound 4 gave a limit, no number; the forecaster's own chance of this, stated with the estimate: 25%; middle value at least 1.7-fold (0.24 log units) away from the limit.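

With cyclohexyl on the amide-type nitrogen, the first saturated ring at this position, this assay gives only a floor for the change from an aromatic ring: an at least 1.8-fold higher number from compound 3 to compound 4 (0.27 log units; that floor lies within the scatter), and likewise an at least 1.8-fold higher number from compound 1 to compound 4 (0.27 log units; that floor lies within the scatter). Both floors stay within the scatter, so the saturated ring cannot be told apart from the aryl groups on these figures, and the step from compound 2 to compound 4 cannot be read at all. Compound 4 gives a limit and not a number, and so does compound 2, which shows that the limit is reached with one aryl group and with the saturated ring alike: the limit of > 300000 nM in this assay, at which 2 of the 4 values shown sit.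

As far as these compounds go, how far compound 4 truly lies from compound 3 stays open, as a limit gives no size. Also open, from the compounds shown here alone, is how this nitrogen would read with a benzyl group, a short alkyl chain, or a ring carrying an amine.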